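Homologating the thiazole ester in a nitropyrimidine series

A few compounds are considered here, and "the series" means these few. Any claim that something is new, unique, unknown or untested is made for them only; others in the source may bear on it.

Compound 1 `CC1(C)CC(NC(=O)c2ccc(Nc3ncc([N+](=O)[O-])c(NC4CCCC4)n3)cc2)CC(C)(C)N1[O]`: 41200 nM
Compound 2 `Cc1cc(Nc2nc(Nc3ccc(C(=O)NC4CC(C)(C)N([O])C(C)(C)C4)cc3)ncc2[N+](=O)[O-])no1`: 26800 nM
Compound 3 `CCOC(=O)c1csc(Nc2nc(Nc3ccc(C(=O)NC4CC(C)(C)N([O])C(C)(C)C4)cc3)ncc2[N+](=O)[O-])n1`: 12500 nM

The three measured compounds share one core and differ only in the group attached to a nitrogen on an aromatic ring. In a functional assay on LoVo cells (Homo sapiens) for antiproliferative activity, read by MTT assay, with a stated time of 48 h (on this read-out lower numbers stand for stronger inhibition and higher numbers for weaker inhibition), compound 3 gives the lowest number of the three. The two steps that reach it are both beyond the scatter: a 3.3-fold lower number from compound 1 to compound 3 (0.52 log units; beyond the scatter) and a 2.1-fold lower number from compound 2 to compound 3 (0.33 log units; beyond the scatter). The remaining pair, a 1.5-fold lower number from compound 1 to compound 2 (0.19 log units; within the scatter), lies within the scatter.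

Compound 4 `CCOC(=O)Cc1csc(Nc2nc(Nc3ccc(C(=O)NC4CC(C)(C)N([O])C(C)(C)C4)cc3)ncc2[N+](=O)[O-])n1` is the next compound and is not yet measured. Relative to compound 3 it carries (ethoxycarbonyl)methyl in place of ethoxycarbonyl on an aromatic carbon. Among the compounds with values here, none of the measured steps touches this position: each of them exchanges the whole group on the ring nitrogen, whereas here the thiazole ring and its attachment are kept and only the substituent on the five-membered ring is lengthened. The measured data therefore give no direct guide. With the rest of the molecule unchanged, compound 4 is expected to stay close to compound 3, with the estimated step of a 1.1-fold higher number from compound 3 to compound 4 (0.05 log units; within the scatter) not beyond the scatter. The estimate for compound 4 in this assay is 14000 nM, within a range from 5000 nM to 40000 nM.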

Compound 4, half-maximal inhibitory concentration: 27000 nM
Estimate against measurement, compound 4: 1.9-fold (0.29 log units) below; the range from low to high includes it.
By their numbers in this assay, from the lowest: compound 3; then compounds 2, 4 and 1 (each within the scatter of the next).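

In this assay, replacing ethoxycarbonyl with (ethoxycarbonyl)methyl on the aromatic carbon next to the ring nitrogen gives a modest step beyond the scatter (a 2.2-fold higher number from compound 3 to compound 4 (0.33 log units; beyond the scatter)), the first sign that the substituent on this five-membered ring matters while the ring and its attachment stay the same. The change also removes the separation that compound 3 had from the other two compounds, since the steps to compound 4 from the 5-methyl-1,2-oxazol-3-yl compound (a 1.0-fold higher number from compound 2 to compound 4 (0.00 log units; within the scatter)) and from the cyclopentyl compound (a 1.5-fold lower number from compound 1 to compound 4 (0.18 log units; within the scatter)) both lie within the scatter. No measurement available here bears on the reason for this step.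

The compounds shown leave open whether the step follows the longer link between ring and ester or the ester itself, a question that a carboxylic acid or an amide on the same carbon could help to address. They also leave open how the number would respond to a longer chain ending in the same ester, and so whether the trend from ethoxycarbonyl to (ethoxycarbonyl)methyl continues.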